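Adding a second fluorine to the urea aryl ring

The compounds below may be only part of what the source reports. "The series", "measured", "known", "first", "only" and "open" are said of these compounds alone.

Three ureas built on the same core have been measured in an ADME assay on the whole organism with Oryza sativa as the target, tested at 10 uM; on this read-out lower numbers stand for a stronger effect and higher numbers for a weaker effect at the one concentration tested. Compound 1 `Cc1ccc(NC(=O)N[C@@H](C)c2ccccc2)cc1` gives 100%, compound 2 `C[C@H](NC(=O)Nc1cccc(F)c1)c1ccccc1` gives 88%, and compound 3 `C[C@H](NC(=O)Nc1ccc(F)cc1)c1ccccc1` gives 85%, the lowest of the three numbers, within the scatter of compound 2 and beyond it from compound 1. Going by the values given here, the one single-point step known, a number 15 percentage points lower from compound 1 to compound 3 (beyond the scatter), was a modest one. Compound 4 `C[C@H](NC(=O)Nc1ccc(F)c(F)c1)c1ccccc1` differs from compound 3 by fluoro in place of hydrogen on an aromatic carbon. Among the compounds with values here, no measured step exchanges hydrogen for fluoro, so the earlier step offers only a loose guide; a second fluoro on the same ring is expected to move this assay little, if at all, with a slight lowering at most. Compound 4 is therefore estimated at 80%, within 65% to 95%, an expected step of a number 5 percentage points lower from compound 3 to compound 4 (within the scatter).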

Compound 4, a percentage reported as activity, at one concentration (the size of the read-out at that concentration, not a potency): 98%
The estimate for compound 4 lay 18 percentage points below the measured number, outside the stated range (above it).
By their numbers in this assay, from the lowest: compounds 3, 2, 4 and 1 (each within the scatter of the next, the first and the last beyond it).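

In this assay, fluoro in place of hydrogen on the aromatic carbon ortho to a fluoro group gives a number 13 percentage points higher from compound 3 to compound 4 (beyond the scatter), the first sign that adding to this ring can weaken the effect rather than leave it in place. Starting from compound 2, the same kind of exchange gives a number 10 percentage points higher from compound 2 to compound 4 (within the scatter), so only one of the two single-step routes to compound 4 shows a change the scatter does not cover. Nothing available accounts for this result.

As far as these compounds go, whether chloro or methoxy at this carbon would read like fluoro remains open. So does whether the rise seen with compound 4 depends on the first fluoro being present.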